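Swapping the Carboxypiperidine for Hydroxy

The source may report more compounds than this note shows. Statements on the series, on what has been measured and on what is new or still open speak of the compounds shown alone.

In a functional assay on MC-38 cells (Mus musculus) for antiproliferative activity, read by CCK-8 assay, with a stated time of 48 h (on this read-out higher numbers stand for weaker inhibition and lower numbers for stronger inhibition), compound 1 (`COc1ccc(/C=C\c2cc(OC)c(OC)c(OC)c2)cc1OCc1ccc(CN2CCCC[C@@H]2C(=O)O)cc1`) gives > 10000 nM, which is a limit of the assay and not a number. Compound 2 (`COc1ccc(/C=C\c2cc(OC)c(OC)c(OC)c2)cc1OCc1ccc(CN2CCCCC2C(=O)NCCNC(=O)OC(C)(C)C)cc1`) gives a true number on the same core, 1900 nM. Compound 3 (`COc1ccc(/C=C\c2cc(OC)c(OC)c(OC)c2)cc1OCc1ccc(CO)cc1`) has hydroxy in place of 2-carboxypiperidin-1-yl on a saturated chain carbon bound to an aromatic carbon. Among the measured compounds shown here, no measured step connects these compounds, so this is a judgement resting on compound 2 at 1900 nM. The expected change is stronger inhibition beyond the usual scatter, an estimated at least 10-fold lower number from compound 1 to compound 3 (1.00 log units; beyond the scatter). For compound 3, the estimated value in this assay is 1000 nM, within a range of 150 nM to 6000 nM.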

Compound 3, half-maximal inhibitory concentration: 5700 nM
For compound 3 the middle estimate is 5.7-fold (0.76 log units) below the measured one; the measured number falls inside the stated range.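

In this assay, hydroxy in place of 2-carboxypiperidin-1-yl on this saturated chain carbon still gives a true number, so a reading at this position does not depend on the piperidine ring. The change can be stated only as a floor, and that floor does not clear the usual scatter: an at least 1.7-fold lower number from compound 1 to compound 3 (0.24 log units; that floor lies within the scatter). Its real size stays unknown because compound 1 stands at a limit: the limit of > 10000 nM in this assay, at which 1 of the 3 values shown sits.

On these data alone, compound 3 gives 5700 nM, and it remains open whether an amine or a methoxy group in place of the hydroxy would move that number.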